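Removing the acetyl group from the piperazine-linked aryl ring

The compounds below may be only part of what the source reports. "The series", "measured", "known", "first", "only" and "open" are said of these compounds alone.

In an ADME assay on RAW264.7 cells (Mus musculus) for cytotoxicity, read by MTT assay, with a stated time of 72 h, tested at 50 ug/mL (a lower number here means less inhibition, a higher number more inhibition at the concentration tested (going by the name of the read-out)), compound 1 `CC(=O)c1ccc(N2CCN(C(=O)c3nc4cc(Cl)ccc4s3)CC2)cc1` gives 30.8%, while compound 2 `CC(=O)c1ccc(N2CCN(C(=O)c3nc4ccccc4s3)CC2)cc1` gives 62.3%. Among the compounds with values here, the one step measured so far, a number 31.5 percentage points higher from compound 1 to compound 2 (beyond the scatter), involves hydrogen in place of chloro on an aromatic carbon. Compound 2 therefore stands highest of the two numbers, with compound 1 the nearer and lower of the pair.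

Compound 3 `O=C(c1nc2ccccc2s1)N1CCN(c2ccccc2)CC1` is yet to be measured in this assay. It differs from compound 2 in one place: hydrogen in place of acetyl on an aromatic carbon. Within the data shown here, no measured step touches the acetyl group, so the step from compound 1 to compound 2 does not bear directly on this change, and it gives no guide to its direction. With nothing to point either way, the expected step of a number 7.3 percentage points lower from compound 2 to compound 3 (within the scatter) is none beyond the scatter, held with little confidence. Compound 3 is thus estimated at 55%, within a range from 30% to 78%.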

Compound 3, a percentage reported as inhibition, at one concentration (the size of the read-out at that concentration, not a potency): 67.2%
Compound 3: the middle estimate sits 12.2 percentage points below what was measured, and the stated range covers the measured number.
By their numbers in this assay, from the lowest: compound 1; then compounds 2 and 3 (each within the scatter of the next).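

In this assay, within the data shown here, the first change at this place, on an aromatic carbon para to a large group, gives a number 4.9 percentage points higher from compound 2 to compound 3 (within the scatter). With the benzene ring otherwise unchanged, acetyl and hydrogen at this place are therefore not told apart by this read-out, whereas the chloro change elsewhere gave a step beyond the scatter, a number 31.5 percentage points higher from compound 1 to compound 2 (beyond the scatter). No supporting measurement is available to account for this result.

The compounds shown leave open whether other groups at this place, such as an amine, a carboxylic acid or a longer chain, would also stay within the scatter of compound 3. They also leave open whether replacing acetyl with hydrogen would give a similarly small step when chloro is present on the core, as in compound 1.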